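The compounds below may be only part of what the source reports. "The series", "measured", "known", "first", "only" and "open" are said of these compounds alone.

Compound 1 `CCCCCCc1ccc(C(=O)/C=C\C(=O)O)cc1`: 252000 nM
Compound 2 `C#CC(=O)Oc1ccc(CCCCCC)cc1`: 18000 nM

Among the compounds with values here, these two values come from a physicochemical assay for solubility, in phosphate buffer (a higher number here means a more soluble compound, a lower number a less soluble compound), and are the only measurements so far. Compound 2 stands lower of the two at 18000 nM, while compound 1 reads higher at 252000 nM, a gap well beyond the scatter.

The next compound, compound 3 `CCCCCCc1ccc(C(=O)C2CO2)cc1`, has not yet been measured. It departs from compound 2 in one place, with (oxiran-2-yl)carbonyl in place of (ethynylcarbonyl)oxy on an aromatic carbon, para to a group of 6 heavy atoms ((oxiran-2-yl)carbonyl in place of (ethynylcarbonyl)oxy on an aromatic carbon). Within the data shown here, no measured pair of compounds differing in one place shows how this assay responds to such a swap. Among the measured compounds shown here, neither group carries a net charge, and the only anchor is compound 2 at 18000 nM, so no step beyond the scatter is expected, in either direction. In numbers, the expected change is a 1.2-fold higher number from compound 2 to compound 3 (0.09 log units; within the scatter) and remains uncertain. The estimated value for compound 3 is 22000 nM, with an expected range from 7000 nM to 70000 nM.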

Compound 3, solubility: 204000 nM
For compound 3 the middle estimate is 9.3-fold (0.97 log units) below the measured one, and the stated range ends below it.
By their numbers in this assay, from the lowest: compound 2; then compounds 3 and 1 (each within the scatter of the next).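

In this assay, (oxiran-2-yl)carbonyl in place of (ethynylcarbonyl)oxy on an aromatic carbon, para to a group of 6 heavy atoms, gives an 11-fold higher number from compound 2 to compound 3 (1.05 log units; beyond the scatter) in this series, so this position responds strongly to the swap even though both groups have the same counts of heavy atoms, hydrogen-bond donors and hydrogen-bond acceptors and neither carries a net charge. The second change, oxiran-2-yl in place of 2-carboxyethenyl on a carbonyl carbon, gives a 1.2-fold lower number from compound 1 to compound 3 (0.09 log units; within the scatter) and stays within the scatter, so this assay does not separate these two groups at that place. Nothing measured here accounts for the large step or for the absence of one in the second change.

The compounds shown leave open which part of the swap carries the large step, since the three-membered ring, the triple bond and the link to the aromatic carbon all change at once. As far as these compounds go, a plain propanoyl group at this position could help to separate these parts, and it remains open how an amine there, or a shorter chain in place of the group of 6 heavy atoms, would read.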